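The compounds below may be only part of what the source reports. "The series", "measured", "known", "first", "only" and "open" are said of these compounds alone.

Compound 1 `COc1ccc(/C=C/C(=O)Nc2cc3c(Nc4ccc(F)c(Cl)c4)ncnc3cc2O[C@H]2CCOC2)c(OC)c1` gives 2760 nM
Compound 2 `N#Cc1ccc(/C=C/C(=O)Nc2cc3c(Nc4ccc(F)c(Cl)c4)ncnc3cc2O[C@H]2CCOC2)cc1` gives 36600 nM
Compound 3 `COc1ccc(OC)c(/C=C/C(=O)Nc2cc3c(Nc4ccc(F)c(Cl)c4)ncnc3cc2O[C@H]2CCOC2)c1` gives 8730 nM

In a functional assay on PC-3 cells (Homo sapiens) for cytotoxicity, read by MTT assay, with a stated time of 72 h (a higher number here means a weaker inhibitor, a lower number a stronger inhibitor), compound 3 holds the middle place of the three, with compound 1 lower and compound 2 higher. Compound 4 `COc1ccc(/C=C/C(=O)Nc2cc3c(Nc4ccc(F)c(Cl)c4)ncnc3cc2O[C@H]2CCOC2)c(OC)c1OC` has, on a double-bonded chain carbon bound to a double-bonded chain carbon, 2,3,4-trimethoxyphenyl in place of the 2,5-dimethoxyphenyl of compound 3 (2,3,4-trimethoxyphenyl in place of 2,5-dimethoxyphenyl on a double-bonded chain carbon bound to a double-bonded chain carbon). Closest in kind is a 3.2-fold higher number from compound 1 to compound 3 (0.50 log units; beyond the scatter) between two dimethoxyphenyl groups, a modest step, whereas the swap to 4-cyanophenyl gave the large 13-fold higher number from compound 1 to compound 2 (1.12 log units; beyond the scatter) instead. The entering group contains the 2,4-dimethoxyphenyl pattern of compound 1 (2760 nM), so a modest step toward a lower number is expected. For compound 4 the expected change is a 2.2-fold lower number from compound 3 to compound 4 (0.34 log units; beyond the scatter) in this estimate. For compound 4 the estimated value is 4000 nM with an expected range of 1200 nM to 13000 nM around it.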

Compound 4, half-maximal inhibitory concentration: 7670 nM
For compound 4 the middle estimate is 1.9-fold (0.28 log units) below the measured one, and the stated range covers the measured number.
By their numbers in this assay, from the lowest: compound 1; then compounds 4 and 3 (each within the scatter of the next); then compound 2.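

In this assay replacing 2,5-dimethoxyphenyl with 2,3,4-trimethoxyphenyl changes nothing that can be told from the scatter (a 1.1-fold lower number from compound 3 to compound 4 (0.06 log units; within the scatter)). Adding a methoxy on an aromatic carbon to the 2,4-dimethoxyphenyl group does not help (a 2.8-fold higher number from compound 1 to compound 4 (0.44 log units; beyond the scatter)), so among these compounds more methoxy groups do not give a lower number, while the trimethoxy compound still clearly beats the 4-cyanophenyl one (a 4.8-fold lower number from compound 2 to compound 4 (0.68 log units; beyond the scatter)). No measurement shown explains these shifts. Still open, from the compounds shown here alone, is how a phenyl group carrying an amine or a carboxylic acid would behave at this place.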